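From a sulfamoylamino group to an oxazolidinone ring

The source may hold more compounds than are shown below. What is called first, only, known or untested is meant among the compounds shown, and "the series" means these compounds.

Measured compounds:
- compound 1, `Cc1nc(N2CCC(NS(=O)(=O)N(C)C)CC2)nc2ccc(NC(=O)/C=C/c3ccc(OC(F)(F)F)cc3)cc12`: 31 nM
- compound 2, `COCCC1(O)CCN(c2nc(C)c3cc(NC(=O)/C=C/c4ccc(Cl)cc4)ccc3n2)CC1`: 220 nM

In a functional assay on CHO-K1 cells for antagonist activity at melanin-concentrating hormone receptor 1 (Homo sapiens), read by inositol phosphate accumulation, with stated times of 10 min and 45 min (on this read-out lower numbers stand for stronger inhibition and higher numbers for weaker inhibition), compound 1 gives 31 nM, the lower of the two numbers recorded. Within the data shown here, compound 2 gives 220 nM in this assay, a higher number that lies beyond the scatter of repeated measurements; the two compounds differ in more than one place, so no single step is drawn between them.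

The step of interest leads from compound 1 to compound 3, `Cc1nc(N2CCC(N3CCOC3=O)CC2)nc2ccc(NC(=O)/C=C/c3ccc(OC(F)(F)F)cc3)cc12`. The change is 2-oxo-1,3-oxazolidin-3-yl in place of (dimethylsulfamoyl)amino on a saturated ring carbon. One polar group on the saturated ring carbon gives way to another of similar size, and the hydrogen-bond donor of the leaving group is lost while the count of acceptors is kept. Among the measured compounds shown here, with no comparable step among the measured compounds, the size of the effect can only be guessed; the expectation is a change from compound 1 to compound 3 of a 1.6-fold higher number from compound 1 to compound 3 (0.21 log units; within the scatter), which is not beyond the scatter in either direction. Compound 3 is therefore expected to give about 50 nM in this assay, with a plausible range from 15 nM to 180 nM.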

Compound 3, half-maximal inhibitory concentration: 31 nM
Compound 3: middle estimate off by 1.6-fold (0.21 log units), on the high side; measured number inside the range.
By their numbers in this assay, from the lowest: compounds 1 and 3 (each within the scatter of the next); then compound 2.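

In this assay, among these compounds, putting 2-oxo-1,3-oxazolidin-3-yl in place of (dimethylsulfamoyl)amino on the saturated ring carbon gives no change at the digits printed from compound 1 to compound 3 (within the scatter), the first single step that can be read at this position, since compound 1 and compound 2 differ in more than one place. The leaving group has 1 hydrogen-bond donor, a sulfur atom and no ring, while the entering group has 0 hydrogen-bond donors, no sulfur and a five-membered non-aromatic ring, yet the two numbers lie within the scatter of each other. In this pair, then, the hydrogen-bond donor of the (dimethylsulfamoyl)amino group is not needed for a number at this level, and the open sulfamide chain can give way to a cyclic group on this carbon with the rest of compound 1 left as it stands.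

Going by these compounds, whether this tolerance reaches other groups on the same carbon, such as a primary amine, a carboxylic acid, a pyrrolidin-2-one ring or a longer ether chain, stays open, as does whether the same exchange reads alike with the 4-chlorophenyl group of compound 2 in place of the 4-(trifluoromethoxy)phenyl group. Nothing at hand gives a reason for the result of this step.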